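Shifting Two Chlorines on the Aryl Group of Compound 1

This account rests on a few compounds, and the source may have more. Where it says the series, first, only, none or still open, it means among the compounds named here.

Compound 1 `Cc1nc(-c2ccccc2)c(C(=O)N2CCN(c3cccc(Cl)c3Cl)CC2)o1`: 133 nM
Compound 2 `COc1ccc(-c2nc(C)oc2C(=O)N2CCN(c3cccc(Cl)c3)CC2)cc1`: "not active" (no number reported)
Compound 3 `CCc1nc(-c2cccc(F)c2)c(C(=O)N2CCN(c3cccc(Cl)c3)CC2)o1`: 317 nM

Three compounds were tested in a functional assay on HL-60 cells (Homo sapiens) for inhibition, read by MTT assay, with a stated time of 72 h; on this read-out lower numbers stand for stronger inhibition and higher numbers for weaker inhibition. Compound 1 gives the lowest of the two numbers reported; compound 3 returns a higher number, and the gap between them lies beyond the usual scatter, while compound 2 returned no number at all. Compound 4 `Cc1nc(-c2ccccc2)c(C(=O)N2CCN(c3ccc(Cl)c(Cl)c3)CC2)o1` has not yet been measured. It contains the same atoms as compound 1, joined differently: 3,4-dichlorophenyl in place of 2,3-dichlorophenyl on an amine nitrogen in a ring. Among the measured compounds shown here, no measured pair shows what such a rearrangement does here, so the change in this assay is expected to be modest, with no firm direction. For compound 4 the expected value is 200 nM, within 60 nM to 700 nM. This corresponds to an expected step of a 1.5-fold higher number from compound 1 to compound 4 (0.18 log units; within the scatter).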

Compound 4, half-maximal inhibitory concentration: 124 nM
Estimate against measurement, compound 4: 1.6-fold (0.21 log units) above, and the stated range covers the measured number.
By their numbers in this assay, from the lowest: compounds 4 and 1 (each within the scatter of the next); then compound 3.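

In this assay, the swap of 2,3-dichlorophenyl for 3,4-dichlorophenyl on the ring amine nitrogen gives a 1.1-fold lower number from compound 1 to compound 4 (0.03 log units; within the scatter). Among the compounds shown here, this is the first pair differing only in how the two chlorines are placed, and the two arrangements cannot be told apart in this assay. No supporting data bear on why the placement makes so little difference here.

Still open is whether both chlorines are needed, since no pair shown isolates one of them. Also open, as far as these compounds go, is how this position would respond to a trifluoromethyl group or a pyridine ring.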